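Seven-membered ring variant of the bicyclic substituent

The source may report more compounds than this note shows. Statements on the series, on what has been measured and on what is new or still open speak of the compounds shown alone.

Compound 3 `CC(=O)N[C@@H]1CCC[C@H](C(=O)Nc2cc(-c3cnc4n3CCC4)c(Cl)cn2)C1` gives the lowest number of the three measured, at 19 uL/min in an ADME assay on cells (Hepatocyte, Rattus norvegicus) for metabolic stability, using equilibrium dialysis; a higher number here means faster removal of the compound, a lower number slower removal. Compound 1 `CC(=O)N[C@@H]1CCC[C@H](C(=O)Nc2cc(-c3cnn4c3CCCC4)c(Cl)cn2)C1` gives 46 uL/min and compound 2 `CC(=O)N[C@@H]1CCC[C@H](C(=O)Nc2cc(-c3cnn4c3CCC4)c(Cl)cn2)C1` gives 72 uL/min; the step of a 1.6-fold higher number from compound 1 to compound 2 (0.19 log units; within the scatter) is within the scatter, while a 2.4-fold lower number from compound 1 to compound 3 (0.38 log units; beyond the scatter) and a 3.8-fold lower number from compound 2 to compound 3 (0.58 log units; beyond the scatter) are beyond it. Compound 4 `CC(=O)N[C@@H]1CCC[C@H](C(=O)Nc2cc(-c3cnn4c3CCCCC4)c(Cl)cn2)C1` differs from compound 3 by a group of 10 heavy atoms (8 carbon, 2 nitrogen; one five-membered aromatic ring with 2 hetero atoms, one seven-membered non-aromatic ring with 1 hetero atom) in place of a group of 8 heavy atoms (6 carbon, 2 nitrogen; one five-membered non-aromatic ring with 1 hetero atom, one five-membered aromatic ring with 2 hetero atoms), on an aromatic carbon. Among the compounds with values here, no measured step tests a seven-membered non-aromatic ring; the nearest comparisons are the six- and five-membered non-aromatic rings of compounds 1 and 2, which sit close together and above compound 3. Compound 4 is therefore expected to move back toward those two, an estimated step of a 2.9-fold higher number from compound 3 to compound 4 (0.46 log units; beyond the scatter). The estimate for compound 4 is 55 uL/min, with a range of 25 uL/min to 120 uL/min.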

Compound 4, intrinsic clearance in a liver preparation (reported as CLH), per the amount of preparation that the assay uses in the Hepatocyte assay: 51 uL/min
For compound 4 the middle estimate is 1.1-fold (0.03 log units) above the measured one, within the range that was stated.
By their numbers in the Hepatocyte assay, from the lowest: compound 3; then compounds 1, 4 and 2 (each within the scatter of the next).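

In the Hepatocyte assay, the seven-membered non-aromatic ring on this aromatic carbon cannot be told apart from the six- and five-membered rings of the same ring family, with a 1.1-fold higher number from compound 1 to compound 4 (0.04 log units; within the scatter) and a 1.4-fold lower number from compound 2 to compound 4 (0.15 log units; within the scatter). Only a 2.7-fold higher number from compound 3 to compound 4 (0.43 log units; beyond the scatter) clears the scatter, so compound 3 stays alone at the low end. In a physicochemical assay for lipophilicity, using the shake flask method, measured as octanol-water partition, at pH 7.4 (on this read-out lower numbers stand for lower lipophilicity and higher numbers for higher lipophilicity), compound 3 gives 2.6 and compound 4 gives 3.6, so this pair differs on both read-outs.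

Going by these compounds, whether the lower clearance of compound 3 follows its hetero atom arrangement or its distribution coefficient stays open. So does the effect of an amine or a hydroxyl group on the non-aromatic ring.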